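The compounds below may be only part of what the source reports. "The series", "measured", "known", "first", "only" and "open" are said of these compounds alone.

The measured compounds and their values:

Compound 1, `CC(C)COC(=O)NS(=O)(=O)Nc1cccc(-c2cc3ccccc3[nH]2)c1`, in an assay for inhibition of Polyunsaturated fatty acid lipoxygenase ALOX15 (Oryctolagus cuniculus), read by spectrophotometry (a higher number here means a weaker inhibitor, a lower number a stronger inhibitor), gives > 50000 nM, a limit of the assay.
Compound 2, `C=CCOC(=O)NS(=O)(=O)Nc1cccc(-c2cc3ccccc3[nH]2)c1`, in this assay gives > 50000 nM, again a limit.
Compound 3, `C=CCOC(=O)NS(=O)(=O)Nc1cc(-c2cc3ccccc3[nH]2)ccc1OC`, in this assay gives 43300 nM.

Compound 2 therefore stands only at a limit, sharing the limit of > 50000 nM in this assay, at which 2 of the 3 values shown sit, with compound 1. The step that the two limits leave unreadable from compound 1 to compound 2 cannot be sized, since both ends are limits. Among the measured compounds shown here, the step of an at least 1.1-fold lower number from compound 2 to compound 3 (0.06 log units; that floor lies within the scatter) is the only one with a readable floor, and that floor sits within the scatter, so none of the measured steps shows a movement beyond the scatter.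

Compound 4, `CCCCCCCCOC(=O)NS(=O)(=O)Nc1cccc(-c2cc3ccccc3[nH]2)c1`, differs from compound 2 by heptyl in place of vinyl on a saturated chain carbon bound to an oxygen next to a carbonyl group. Neither measured step bears directly on such a chain extension: the step from compound 1 to compound 2 at the same place is unreadable, and the step from compound 2 to compound 3 concerns another site. No direction can be inferred from the data.

Compound 4 is therefore expected to remain near the limit, with an estimated 50000 nM in this assay, the range running from 15000 nM to 150000 nM. The expected step of a number no higher from compound 2 to compound 4 (the limit leaves the size open) is within the scatter.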

Compound 4, half-maximal inhibitory concentration: 2790 nM
Estimate against measurement, compound 4: 18-fold (1.25 log units) above; the measured number lies below the stated range.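

Among the compounds shown here, at this place, on a saturated chain carbon bound to an oxygen next to a carbonyl group, the chain is the first change to move this assay beyond the scatter: heptyl in place of vinyl gives an at least 17-fold lower number from compound 2 to compound 4 (1.25 log units; beyond the scatter), and heptyl in place of isopropyl gives an at least 17-fold lower number from compound 1 to compound 4 (1.25 log units; beyond the scatter). Before compound 4, the one step at this place, between compound 1 and compound 2, could not be read, and the methoxy step on the aromatic carbon showed nothing beyond the scatter. Both new steps are floors only, and their true sizes stay open: the limit of > 50000 nM in this assay, at which 2 of the 4 values shown sit.

The compounds shown leave open whether the number keeps falling with a longer chain such as decyl, or how a chain ending in a carboxylic acid or an amine would behave. They also leave open how methoxy on the aromatic carbon would act together with the heptyl group.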